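The source may report more compounds than this note shows. Statements on the series, on what has been measured and on what is new or still open speak of the compounds shown alone.

Compound 1 `CC(C)(C)c1ccc(-c2cn(C/C=C3\OC(=O)C(OCc4ccccc4)=C3OCc3ccccc3)nn2)cc1` belongs to a small set tested in a functional assay on HCT-116 cells (Homo sapiens) for antiproliferative activity, read by MTT assay, with a stated time of 24 h; on this read-out lower numbers stand for stronger inhibition and higher numbers for weaker inhibition. In this assay compound 1 gives only > 100000 nM, which is a limit of the assay rather than a number. Compound 1 thus stands at the limit of > 100000 nM in this assay, at which 2 of the 3 values shown sit. Compound 2 `O=C1NC(O)(CCn2cc(-c3ccccc3)nn2)C(OCc2ccccc2)=C1OCc1ccccc1` gives 53400 nM in this assay. Compound 3 `CC(C)(C)c1ccc(-c2cn(CCC3(O)NC(=O)C(OCc4ccccc4)=C3OCc3ccccc3)nn2)cc1` gives > 100000 nM, also a limit. For the measured compounds named here, the single measured step that touches the same region, an at least 1.8-fold higher number from compound 2 to compound 3 (0.27 log units; that floor lies within the scatter), shows that adding tert-butyl on the aromatic carbon did not help. Compound 4 `O=C1O/C(=C\Cn2cc(-c3ccccn3)nn2)C(OCc2ccccc2)=C1OCc1ccccc1` differs from compound 1 by pyridin-2-yl in place of 4-(tert-butyl)phenyl on an aromatic carbon. Removing the tert-butyl group is expected to move the number down modestly, giving an expected step of an at least 1.6-fold lower number from compound 1 to compound 4 (0.22 log units; that floor lies within the scatter). Compound 4 is therefore estimated at 60000 nM, with a range from 15000 nM to 200000 nM.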

Compound 4, half-maximal inhibitory concentration: > 100000 nM
Compound 4: no number, only a limit; the forecaster's own chance of this, stated with the estimate: 45%; middle value at least 1.6-fold (0.22 log units) away from the limit.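

Compound 1 and compound 4 both give only a limit, not a number, so the step between them cannot be read: the limit of > 100000 nM in this assay, at which 3 of the 4 values shown sit. The compounds shown leave open how pyridin-2-yl and 4-(tert-butyl)phenyl truly compare on this core.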